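The compounds below may be only part of what the source reports. "The series", "measured", "known", "first", "only" and "open" are said of these compounds alone.

- compound 1 `CCCCCCNC(=O)c1cc(NCc2cc(O)ccc2O)ccc1O`: 2300 nM
- compound 2 `O=C(NCc1ccccc1)c1cc(NCc2cc(O)ccc2O)ccc1O`: 21000 nM

The lower of the two numbers in a functional assay on SF-539 cells (Homo sapiens) for cytotoxicity (on this read-out lower numbers stand for stronger inhibition of growth and higher numbers for weaker inhibition of growth), belongs to compound 1. For the measured compounds named here, the only measured step is a 9.1-fold higher number from compound 1 to compound 2 (0.96 log units; beyond the scatter), and it records phenyl in place of pentyl on the chain attached to the amide-type nitrogen.

Compound 3 `CCCCCCCCCCCCNC(=O)c1cc(NCc2cc(O)ccc2O)ccc1O` keeps the core of compound 1 and differs only in its chain: hexyl in place of hydrogen on a saturated chain carbon, six bonds along the chain from an amide-type nitrogen. The measured step bears on this change only loosely. It shows that altering the chain can move the number in this assay beyond the scatter, but it swaps in a phenyl group and does not lengthen a saturated chain. Going by the values given here, no measured pair shows what hexyl in place of hydrogen does at this carbon, so the data give no direction. The best expectation is therefore no step beyond the scatter, with real room for movement either way. The expected step is a 1.1-fold higher number from compound 1 to compound 3 (0.04 log units; within the scatter). For compound 3 the estimated value is 2500 nM, with an expected range from 500 nM to 15000 nM.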

Compound 3, concentration for 50% growth inhibition: 20000 nM
The estimate for compound 3 lay 8.0-fold (0.90 log units) below the measured number, and the stated range ends below it.
By their numbers in this assay, from the lowest: compound 1; then compounds 3 and 2 (each within the scatter of the next).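

In this assay, hexyl in place of hydrogen on this saturated chain carbon, six bonds along the chain from an amide-type nitrogen, gives an 8.7-fold higher number from compound 1 to compound 3 (0.94 log units; beyond the scatter). This shows that the position responds to lengthening the saturated chain alone, which the earlier pair could not show, as its change put phenyl in place of pentyl. Set beside a 9.1-fold higher number from compound 1 to compound 2 (0.96 log units; beyond the scatter), it means that both changes to the chain of compound 1 lead to weaker inhibition of growth, one introducing a ring and the other only further chain carbons. Nothing available accounts for the rise in the number with the longer chain.

The compounds shown leave open how the number behaves between the chains of compound 1 and compound 3, and whether an octyl chain would stay close to compound 1 or already sit near compound 3. They also leave open whether a shorter butyl chain would give a lower number than compound 1, and what a chain ending in an amine or a carboxylic acid would do at this position.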